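Extending the Amide Arm of Compound 1

This account rests on a few compounds, and the source may have more. Where it says the series, first, only, none or still open, it means among the compounds named here.

Compound 1 `COc1cc2nc(N3CCC(C(=O)NC4CCCC4)CC3)nc(N)c2cc1OC` is the reference point of this small set. In an assay on isolated protein for displacement of a labelled ligand from Adrenergic receptor alpha-1 (Rattus norvegicus) (on this read-out lower numbers stand for stronger inhibition and higher numbers for weaker inhibition), compound 1 gives 0.63 nM, the lowest of the three numbers. Its closest neighbour is compound 2 `COc1cc2nc(N3CCC(C(=O)NCC4CC4)CC3)nc(N)c2cc1OC`, which in this assay gives 0.9 nM; the step of a 1.4-fold higher number from compound 1 to compound 2 (0.15 log units; within the scatter), cyclopropylmethyl in place of cyclopentyl on an amide-type nitrogen, stays within the scatter. Compound 3 `CCCCNC(=O)CC1CCN(c2nc(N)c3cc(OC)c(OC)cc3n2)CC1` gives 1.4 nM in this assay, and the step of a 2.2-fold higher number from compound 1 to compound 3 (0.35 log units; beyond the scatter), (butylcarbamoyl)methyl in place of cyclopentylcarbamoyl on a saturated ring carbon, is the only one in the set beyond the scatter, though modest. Between compounds 2 and 3 the step of a 1.6-fold higher number from compound 2 to compound 3 (0.19 log units; within the scatter) is within the scatter.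

Compound 4 `CCCCNC(=O)COC1CCN(c2nc(N)c3cc(OC)c(OC)cc3n2)CC1` has not yet been measured. It differs from compound 1 as follows: (butylcarbamoyl)methoxy in place of cyclopentylcarbamoyl on a saturated ring carbon. Among the compounds with values here, this change closely resembles the one from compound 1 to compound 3, which carried a modest loss, a 2.2-fold higher number from compound 1 to compound 3 (0.35 log units; beyond the scatter), and compound 4 carries the related (butylcarbamoyl)methoxy group. Within the data shown here, the nearest precedent therefore points to a modest rise in the number, with no step in the set suggesting a gain. Compound 4 is expected to give 1.8 nM in this assay, with a plausible range from 0.8 nM to 4 nM. That estimate corresponds to the expected step of a 2.9-fold higher number from compound 1 to compound 4 (0.46 log units; beyond the scatter).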

Compound 4, inhibition constant: 0.79 nM
Estimate against measurement, compound 4: 2.3-fold (0.36 log units) above; the whole stated range lies above it.
By their numbers in this assay, from the lowest: compounds 1, 4, 2 and 3 (each within the scatter of the next, the first and the last beyond it).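

In this assay, the step of a 1.3-fold higher number from compound 1 to compound 4 (0.10 log units; within the scatter) shows that this saturated ring carbon can carry the open-chain (butylcarbamoyl)methoxy group in place of cyclopentylcarbamoyl, with its five-membered ring gone, and stay within the scatter of compound 1, which compound 3 with its (butylcarbamoyl)methyl group did not do. Within the data shown here, the single change in the arm of compound 3, seen in the step of a 1.8-fold lower number from compound 3 to compound 4 (0.25 log units; within the scatter), also stays within the scatter, as does the step of a 1.1-fold lower number from compound 2 to compound 4 (0.06 log units; within the scatter), so (butylcarbamoyl)methoxy cannot be told apart from (butylcarbamoyl)methyl or (cyclopropylmethyl)carbamoyl at this position. No supporting evidence is available on why this position accepts these different arms.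

Every arm shown still holds a carbonyl and an amide hydrogen, so it remains open whether a carboxylic acid or an amine at the same place would keep the number in this range. It is also open how far the arm can grow, since a longer chain than butyl on the amide nitrogen does not appear among these compounds.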